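The compounds below may be only part of what the source reports. "The series", "measured", "known", "first", "only" and "open" are said of these compounds alone.

In a functional assay on A549 cells (Homo sapiens) for antiproliferative activity, read by MTT assay, with a stated time of 48 h (on this read-out higher numbers stand for weaker inhibition of growth and lower numbers for stronger inhibition of growth), compound 1 (`CCOc1cc(NC(=O)CCCCCC(=O)Nc2cc(-c3ccccc3)ccc2N)cc2c1OCC([N+](=O)[O-])=C2`) gives 4860 nM and compound 2 (`CCOc1cc(NC(=O)CCCCC(=O)Nc2cc(-c3ccccc3)ccc2N)cc2c1OCC([N+](=O)[O-])=C2`) gives 7460 nM. These two numbers lie within the scatter of each other, so compound 2 stands level with compound 1. Compound 3 (`CCOc1cc(NC(=O)CCCCC(=O)Nc2ccccc2N)cc2c1OCC([N+](=O)[O-])=C2`) differs from compound 2 in one place: hydrogen in place of phenyl on an aromatic carbon, with hydrogen in place of phenyl on an aromatic carbon. Among the compounds with values here, no measured pair shows this change, so no step beyond the scatter is expected, in either direction. The expected change is a 1.5-fold lower number from compound 2 to compound 3 (0.17 log units; within the scatter). For compound 3, the estimated value is 5000 nM, within a range of 1600 nM to 15000 nM.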

Compound 3, concentration for 50% growth inhibition: 9630 nM
For compound 3 the middle estimate is 1.9-fold (0.28 log units) below the measured one; the range from low to high includes it.
By their numbers in this assay, from the lowest: compounds 1, 2 and 3 (each within the scatter of the next).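

Replacing the phenyl on this aromatic carbon, para to an amino group, with hydrogen gives a 1.3-fold higher number from compound 2 to compound 3 (0.11 log units; within the scatter) in this assay. Phenyl and hydrogen therefore stand level at this position, so the loss of this whole aromatic ring does not move the number beyond the scatter. Nothing available accounts for this result. Still open, on these data alone, is whether a different group here, such as a fluorine, an amine or a carboxylic acid, would give a step beyond the scatter. Also open, as far as these compounds go, is whether hydrogen at this position would stand level with phenyl when paired with the longer chain of compound 1.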